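Amine swap on the amide side chain across two cores

A few compounds are considered here, and "the series" means these few. Any claim that something is new, unique, unknown or untested is made for them only; others in the source may bear on it.

Measured so far:
compound 1 `CCNCC(=O)Nc1cc(OC)ccc1C(=O)c1ccc(OC)c2c1OC(C)(C)C=C2`: 2690 nM
compound 2 `CCNCC(=O)Nc1cc(OC)ccc1C(=O)c1ccc(OC)c2c1C=CC(C)(C)O2`: 4270 nM
compound 3 `COc1ccc(C(=O)c2ccc(OC)c3c2OC(C)(C)C=C3)c(NC(=O)CN(C)C)c1`: 1050 nM

All values come from a functional assay on HeLa cells (Homo sapiens) for antiproliferative activity, read by MTT assay, with a stated time of 48 h; a lower number here means a stronger inhibitor, a higher number a weaker inhibitor. Going by the values given here, the one counted step in hand is a 2.6-fold lower number from compound 1 to compound 3 (0.41 log units; beyond the scatter), the change being (dimethylamino in place of ethylamino on a saturated chain carbon bound to a carbonyl carbon). Compound 1 and compound 2 hold the same atoms joined differently; the difference between the two cores is not broken down here. In this assay compound 2 and compound 1 give numbers within the scatter of each other, while compound 3 gives the lowest number of the three.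

Compound 4 `COc1ccc(C(=O)c2ccc(OC)c3c2C=CC(C)(C)O3)c(NC(=O)CN(C)C)c1` is not yet measured. It stands to compound 2 as compound 3 stands to compound 1: dimethylamino in place of ethylamino on a saturated chain carbon bound to a carbonyl carbon, the same change at the same place. For compound 4 the expected step is a 2.6-fold lower number from compound 2 to compound 4 (0.41 log units; beyond the scatter), resting on the measured 2.6-fold lower number from compound 1 to compound 3 (0.41 log units; beyond the scatter) on the other core. Compound 4 is therefore estimated at 1650 nM, with a likely range from 800 nM to 3500 nM.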

Compound 4, half-maximal inhibitory concentration: 3620 nM
For compound 4 the middle estimate is 2.2-fold (0.34 log units) below the measured one; measured number above the stated range.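

In this assay dimethylamino in place of ethylamino on the core of compound 2 gives a 1.2-fold lower number from compound 2 to compound 4 (0.07 log units; within the scatter). Set beside the same change on the core of compound 1, the two steps cannot be told apart: the same change on two cores in this assay, a 2.6-fold lower number (0.41 log units; beyond the scatter) from compound 1 to compound 3 and a 1.2-fold lower number (0.07 log units; within the scatter) from compound 2 to compound 4, 2.2-fold (0.34 log units) apart, within the scatter of two such steps. Going by these compounds alone, the result therefore does not show that the core alters this change, but neither does it show that the change carries over intact, with a single pair on each core and only one step lying beyond the scatter.

Still open, as far as these compounds go, is how other amines on the same chain, such as pyrrolidine or morpholine, behave on the two cores. From the compounds shown here alone, a longer chain carrying the dimethylamino group also remains open.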